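The source may hold more compounds than are shown below. What is called first, only, known or untested is meant among the compounds shown, and "the series" means these compounds.

Measured compounds:
compound 1 `COc1cc(NS(=O)(=O)c2ccc(C)cc2[N+](=O)[O-])c2ncccc2c1` gives 7600 nM
compound 2 `COc1ccc(S(=O)(=O)Nc2cccc3ccc(C)nc23)c([N+](=O)[O-])c1` gives "not determined" (no result reported)
compound 3 `O=S(=O)(Nc1cccc2cccnc12)c1cccs1` gives 9000 nM

For the measured compounds named here, in an assay on OCI-Ly3 cells for activation of NF-kappa-B inhibitor alpha (Homo sapiens), read by a luciferase reporter (a higher number here means that more compound is needed for the effect, a lower number that less compound is needed), only two numbers stand, and compound 3 with 9000 nM and compound 1 with 7600 nM lie within the usual scatter of each other, so neither can be set above the other. Compound 2 has no result in this assay and adds nothing to the comparison. From compound 3 the step goes to compound 4 `O=S(=O)(Nc1cccc2cccnc12)c1ccc(Cl)s1`, which differs by chloro in place of hydrogen on an aromatic carbon, that is, thiophen-2-yl becomes 5-chlorothiophen-2-yl. Going by the values given here, no step between measured compounds shows what such a change does here, so the expectation rests on the unchanged remainder shared with compound 3. The step from compound 3 to compound 4 is expected to be small, a 1.5-fold lower number from compound 3 to compound 4 (0.18 log units; within the scatter), leaning toward a lower number but not clearly beyond the scatter. Compound 4 is therefore estimated at 6000 nM, with a range from 2000 nM to 18000 nM.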

Compound 4, half-maximal effective concentration: 2700 nM
Beside the measured number, compound 4's estimate is 2.2-fold (0.35 log units) above it; low and high end bracket the measured number.
By their numbers in this assay, from the lowest: compound 4; then compounds 1 and 3 (each within the scatter of the next).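

In this assay, for the compounds shown here, replacing hydrogen with chloro on the thiophene carbon next to the ring sulfur, so that thiophen-2-yl becomes 5-chlorothiophen-2-yl, gives a 3.3-fold lower number from compound 3 to compound 4 (0.52 log units; beyond the scatter), a modest change and the first step in this set that can be read. It shows that this position responds to a single added chlorine atom, with less compound needed for the effect, and that the position accepts a group other than hydrogen in this assay. Nothing measured here explains the shift.

Going by these compounds, it remains open whether a bromo, a methyl, an amine or a carboxylic acid on the same carbon would move the number in the same direction or by a similar amount. The finding rests on this one pair, so it is also unknown whether chloro would have a similar effect on a different core.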